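A few compounds are considered here, and "the series" means these few. Any claim that something is new, unique, unknown or untested is made for them only; others in the source may bear on it.

In an assay on isolated protein for inhibition of protein kinase C zeta type (Homo sapiens), with stated times of 1 h and 2.5 min, tested at 30 uM (on this read-out higher numbers stand for more inhibition at the one concentration tested (going by the name of the read-out) and lower numbers for less inhibition), three compounds have been examined. Compound 1 `COc1ccc(-c2csc(N)c2C(=O)OCc2ccccc2)cc1OC` gives 100%, compound 2 `CCOC(=O)c1c(-c2cccc(OC)c2)csc1N` gives 82%, and compound 3 `Cc1ccc(-c2csc(N)c2C(=O)OCc2ccccc2)cc1` gives 60%, the lowest of the three numbers, with compound 2 standing beyond the scatter above it and compound 1 further still. Compound 4 `COc1cccc(-c2csc(N)c2C(=O)OCc2ccccc2)c1` has not yet been measured. It differs from compound 3 in one place: 3-methoxyphenyl in place of 4-methylphenyl on an aromatic carbon. Within the data shown here, no step between measured compounds separates these two groups, so the size of the change is open; but compound 2, which also carries a 3-methoxyphenyl group, gives 82%, above compound 3. The step from compound 3 to compound 4 is therefore expected to be upward and beyond the scatter, at a number 22 percentage points higher from compound 3 to compound 4 (beyond the scatter). Compound 4 is estimated at 82%, within a range from 58% to 100%.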

Compound 4, a percentage reported as inhibition, at one concentration (the size of the read-out at that concentration, not a potency): 57%
Compound 4: middle estimate off by 25 percentage points, on the high side; the measured number lies below the stated range.
By their numbers in this assay, from the lowest: compounds 4 and 3 (each within the scatter of the next); then compound 2; then compound 1.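

In this assay, 3-methoxyphenyl in place of 4-methylphenyl on an aromatic carbon gives a number 3 percentage points lower from compound 3 to compound 4 (within the scatter) and so shows no separation between these two groups at this position. With 3-methoxyphenyl held fixed, phenyl in place of methyl on the saturated chain carbon bound to an oxygen gives a number 25 percentage points lower from compound 2 to compound 4 (beyond the scatter) and shows that the number of compound 2 does not carry over to the phenyl-bearing chain. Hydrogen in place of methoxy on an aromatic carbon gives a number 43 percentage points lower from compound 1 to compound 4 (beyond the scatter) as the largest of these steps.

No measurement shown explains any of these steps. From the compounds shown here alone, whether an amine or a carboxylic acid on the aromatic ring would match the methoxy of compound 1 stays open.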